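The source may hold more compounds than are shown below. What is called first, only, known or untested is meant among the compounds shown, and "the series" means these compounds.

Of the compounds shown here, three built on the same core have been measured in an assay on isolated protein for inhibition of Voltage-dependent L-type calcium channel subunit alpha-1C (Cavia porcellus); a lower number here means a stronger inhibitor, a higher number a weaker inhibitor. Compound 1 `CCCOC(=O)C1=C(C)NC(C)=C(C(=O)OCCC)C1c1[nH]cnc1Cl` gives 63.1 nM, the lowest of the three numbers. Compound 2 `CC1=C(C(=O)OC2CCCC2)C(c2[nH]cnc2Cl)C(C(=O)OC2CCCC2)=C(C)N1` gives 97.7 nM, which lies within the scatter of compound 1. Compound 3 `CC1=C(C(=O)OCC2CCCCC2)C(c2[nH]cnc2Cl)C(C(=O)OCC2CCCCC2)=C(C)N1` gives 631 nM, a number beyond the scatter from compound 1. Compound 4 `CCCOC(=O)C1=C(C)NC(C)=C(C(=O)OCC)C1c1[nH]cnc1Cl` has not been measured; it differs from compound 1 by hydrogen in place of methyl on a saturated chain carbon, two bonds along the chain from an oxygen next to a carbonyl group. With one ester chain merely shortened and the rest of the molecule unchanged, no step beyond the scatter is expected in either direction. For compound 4 the expected step is a 1.1-fold higher number from compound 1 to compound 4 (0.05 log units; within the scatter). Compound 4 is therefore estimated at 70 nM, with a range from 25 nM to 200 nM.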

Compound 4, half-maximal inhibitory concentration: 407 nM
Beside the measured number, compound 4's estimate is 5.8-fold (0.76 log units) below it, and the stated range ends below it.
By their numbers in this assay, from the lowest: compounds 1 and 2 (each within the scatter of the next); then compounds 4 and 3 (each within the scatter of the next).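

In this assay, shortening a single ester chain from propoxy to ethoxy gives a 6.5-fold higher number from compound 1 to compound 4 (0.81 log units; beyond the scatter), so the loss of this one methyl is not a silent change at this position. The earlier compounds shown here carried the same ester on both sides, and so could not show what changing one chain alone does. Nothing available accounts for the size of this step.

Still open, on these data alone, is whether shortening the remaining propoxy chain to ethoxy adds a further step, and how a methoxy or a longer butoxy chain would read at this position.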